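The source may hold more compounds than are shown below. What is called first, only, known or untested is meant among the compounds shown, and "the series" means these compounds.

In a functional assay on DU-145 cells (Homo sapiens) for inhibition, read by CCK-8 assay, with a stated time of 72 h (a higher number here means a weaker inhibitor, a lower number a stronger inhibitor), compound 1 `O=C(/C=C/c1cccnc1)NCCCCCCCc1ccc(S(=O)(=O)Nc2ccccc2)cc1` reads 438 nM and compound 2 `Cc1ccc(NS(=O)(=O)c2cccc(CCCCCCNC(=O)/C=C/c3cccnc3)c2)cc1` reads 34.4 nM in these notes on the series. Compound 3 `Cc1ccc(C)c(NS(=O)(=O)c2cccc(CCCCCCNC(=O)/C=C/c3cccnc3)c2)c1` reads 7.48 nM and is the lowest of the three numbers, clear of both others by more than the usual scatter.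

Compound 4 `O=C(/C=C/c1cccnc1)NCCCCCCc1cccc(S(=O)(=O)Nc2ccc(F)cc2)c1` is the next to be read. Its difference from compound 3 is 4-fluorophenyl in place of 2,5-dimethylphenyl on a sulfonamide nitrogen and amounts to 4-fluorophenyl in place of 2,5-dimethylphenyl on a sulfonamide nitrogen.

Within the data shown here, one measured step bears directly on this place: a 4.6-fold lower number from compound 2 to compound 3 (0.66 log units; beyond the scatter) on bringing in 2,5-dimethylphenyl in place of 4-methylphenyl. Compound 4 gives up that same group, so a rise in the number of similar size is expected, back towards compound 2 at 34.4 nM. Compound 1 differs from compound 3 in more than the group on the nitrogen and offers no clean comparison. Among the measured compounds shown here, no measured compound carries 4-fluorophenyl, so treating it like 4-methylphenyl is an assumption, and the range is kept wide.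

The expected change is a 3.7-fold higher number from compound 3 to compound 4 (0.57 log units; beyond the scatter) on this reading. The estimate for compound 4 is 28 nM with 10 nM to 80 nM as the expected range.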

Compound 4, half-maximal inhibitory concentration: 10.6 nM
Estimate against measurement, compound 4: 2.6-fold (0.42 log units) above, within the range that was stated.
By their numbers in this assay, from the lowest: compounds 3 and 4 (each within the scatter of the next); then compound 2; then compound 1.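

In this assay, 4-fluorophenyl in place of 2,5-dimethylphenyl on the sulfonamide nitrogen gives a 1.4-fold higher number from compound 3 to compound 4 (0.15 log units; within the scatter), so a low number at this place does not depend on 2,5-dimethylphenyl. Fluoro in place of methyl on an aromatic carbon gives a 3.2-fold lower number from compound 2 to compound 4 (0.51 log units; beyond the scatter), showing that this single exchange on the ring is enough to move the number beyond the scatter. Compound 2 therefore has a higher number than both compound 3 and compound 4, while the last two cannot be ordered; among these three groups, the 4-methylphenyl of compound 2 is the one that stands apart, and that holds for these compounds only.

Nothing available explains either step, and the data give no cause for the readings. Among these compounds, still open is how 4-chlorophenyl, 4-methoxyphenyl or 2,5-difluorophenyl would read on the same sulfonamide nitrogen, and whether 4-fluorophenyl would keep its standing on a longer chain than the one in compound 4.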